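The source may hold more compounds than are shown below. What is called first, only, known or untested is meant among the compounds shown, and "the series" means these compounds.

Of the compounds shown here, three sharing one core have been measured in a physicochemical assay for lipophilicity, read by LC-MS, in phosphate buffer, measured as octanol-water partition, with a stated time of 30 min, at pH 7.4, tested at 200 mM; on this read-out lower numbers stand for lower lipophilicity and higher numbers for higher lipophilicity. Compound 1 `Cc1ccc(Oc2ccc3nc(COc4cccc(C(=O)O)c4)n(C)c3c2)nc1` gives 0.9. Compound 2 `Cn1c(COc2cccc(C(=O)O)c2)nc2ccc(Oc3ccc(F)cn3)cc21` gives 0.6. Compound 3 `Cn1c(COc2cccc(C(=O)O)c2)nc2ccc(Oc3ncc(Cl)cc3F)cc21` gives 1.3, and stands a number 0.40 log units higher from compound 1 to compound 3 (beyond the scatter) and a number 0.70 log units higher from compound 2 to compound 3 (beyond the scatter).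

Compound 4 `Cc1cc(Cl)cnc1Oc1ccc2nc(COc3cccc(C(=O)O)c3)n(C)c2c1` has not yet been measured in this assay. It arises from compound 3 by methyl in place of fluoro on an aromatic carbon. The same kind of change, made once before, is methyl in place of fluoro on an aromatic carbon, with a number 0.30 log units higher from compound 2 to compound 1 (within the scatter). The cores differ by 5-chloro-3-fluoropyridin-2-yl in place of 5-fluoropyridin-2-yl on an oxygen on an aromatic ring, and the surroundings differ: in compound 4 the site is ortho to a large group and meta to a chloro group, whereas in compound 1 it is para to a large group. A step of similar size is expected, a number 0.30 log units higher from compound 3 to compound 4 (within the scatter), because compound 2 to compound 1 gave a number 0.30 log units higher from compound 2 to compound 1 (within the scatter). Compound 4 is therefore estimated at 1.6, between 1.2 and 2.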

Compound 4, distribution coefficient: 1.8
For compound 4 the middle estimate is 0.20 log units below the measured one; measured number inside the range.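

In this assay, methyl in place of fluoro gives a number 0.50 log units higher from compound 3 to compound 4 (beyond the scatter) on one core, beyond the scatter, whereas the same change gave a number 0.30 log units higher from compound 2 to compound 1 (within the scatter) on the other core, within the scatter. Exchanges of the whole pyridinyl group span a number 1.20 log units higher from compound 2 to compound 4 (beyond the scatter) and a number 0.90 log units higher from compound 1 to compound 4 (beyond the scatter) but do not isolate the methyl for fluoro change. Two pairs show that this change need not read alike on both cores, but they give no rule for carrying it further, and nothing measured here explains the difference between them.

The compounds shown leave open how a methoxy or trifluoromethyl group would read on this aromatic carbon. They also leave open whether the same change would read alike on a core with an amide in place of the carboxylic acid.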